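Replacing Ethoxycarbonyl with Hydroxymethyl in a Cytotoxicity Series

The source may report more compounds than this note shows. Statements on the series, on what has been measured and on what is new or still open speak of the compounds shown alone.

In a functional assay on K562 cells (Homo sapiens) for cytotoxicity, read by MTT assay, with a stated time of 48 h (a lower number here means a stronger inhibitor, a higher number a weaker inhibitor), compound 1 `CCOC(=O)C1(C(=O)Nc2ccccc2)CC1c1cc(OC)c(OC)c(OC)c1` gives > 100000 nM; > 100000 nM (2 entries), which is a limit of the assay and not a number. Drawn with a defined configuration, compound 2 `CCOC(=O)[C@]1(C(=O)Nc2ccccc2)C[C@@H]1c1cc(OC)c(OC)c(OC)c1` gives > 100000 nM, again only a limit. Compound 2 therefore offers no number from which to measure a change.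

Compound 3 `COc1cc([C@H]2C[C@]2(CO)C(=O)Nc2ccccc2)cc(OC)c1OC` carries hydroxymethyl in place of ethoxycarbonyl on a saturated ring carbon of the shared core: hydroxymethyl in place of ethoxycarbonyl on a saturated ring carbon. Among the measured compounds shown here, no measured step between compounds is available to size this replacement. With only the limit of compound 2 at > 100000 nM to go on, no step beyond the scatter is expected in this assay, in either direction. The expected step is a number no higher from compound 2 to compound 3 (the limit leaves the size open), and a further limit would be no surprise. Compound 3 is estimated at 100000 nM, with an expected range of 30000 nM to 300000 nM.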

Compound 3, half-maximal inhibitory concentration: > 100000 nM
Compound 3: a limit, no number (the forecaster's own chance of this, stated with the estimate: 70%); the middle value lies on the limit itself.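

Compound 2 and compound 3 both end at a limit of the assay and not at a number, so no step between them can be read: the limit of > 100000 nM in this assay, at which 2 of the 3 values shown sit.

The compounds shown leave open whether hydroxymethyl in place of ethoxycarbonyl on a saturated ring carbon changes the value at all.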